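The source may report more compounds than this note shows. Statements on the series, on what has been measured and on what is new or still open speak of the compounds shown alone.

Measured in a functional assay on Huh-7 cells (Homo sapiens) for inhibition, read by MTT assay, with a stated time of 48 h; on this read-out lower numbers stand for stronger inhibition and higher numbers for weaker inhibition:

- Compound 1 `COc1ccc2c(=O)c(/C=C/C(=O)Nc3cccc(C)c3)coc2c1`: 15500 nM
- Compound 2 `O=C(/C=C/c1coc2cc(O)ccc2c1=O)NCc1ccccc1`: 4690 nM
- Compound 3 `COc1ccc2c(=O)c(/C=C/C(=O)Nc3ccccc3Cl)coc2c1`: 58400 nM

Of these three, compound 3 has the highest number and is therefore the weakest inhibitor in this assay. Its gaps to compound 1 and compound 2 both lie beyond the usual scatter.

The next compound, compound 4 `COc1ccc2c(=O)c(/C=C/C(=O)NCc3cccc(F)c3)coc2c1`, keeps the core of compound 3 but has 3-fluorobenzyl in place of 2-chlorophenyl on an amide-type nitrogen.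

For the measured compounds named here, only one measured step changes the group at this place with the core held constant. This is a 3.8-fold higher number from compound 1 to compound 3 (0.58 log units; beyond the scatter), so a swap here can move the number beyond the scatter. Compound 2, at 4690 nM, also has a benzyl group on that nitrogen, but its core differs and it has no fluorine, so it offers only a loose guide. With so few compounds, any expectation remains tentative. A modest move towards stronger inhibition seems most likely, with the expected change being a 4.2-fold lower number from compound 3 to compound 4 (0.62 log units; beyond the scatter). For compound 4 the estimated value is 14000 nM, with an expected range of 4000 nM to 45000 nM.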

Compound 4, half-maximal inhibitory concentration: 10100 nM
The estimate for compound 4 lay 1.4-fold (0.14 log units) above the measured number; the range from low to high includes it.
By their numbers in this assay, from the lowest: compound 2; then compounds 4 and 1 (each within the scatter of the next); then compound 3.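

In this assay, the amide-type nitrogen on the shared core can carry 3-fluorobenzyl in place of 2-chlorophenyl with a clear gain, seen as a 5.8-fold lower number from compound 3 to compound 4 (0.76 log units; beyond the scatter). Set against 3-methylphenyl on the same core, 3-fluorobenzyl gives a 1.5-fold lower number from compound 1 to compound 4 (0.19 log units; within the scatter), so these two groups cannot be told apart here, and of the three groups on this core only 2-chlorophenyl stands apart, with the highest number. No measurement at hand gives a reason for these steps, so they remain a description of the numbers alone.

The change from 2-chlorophenyl to 3-fluorobenzyl alters several things at once, including the ring substituent, its place on the ring and the carbon that joins the ring to the nitrogen, so the compounds shown cannot say which of these matters; plain benzyl on the same core would help to separate them. Also open, from the compounds shown here alone, is how this nitrogen responds to a group with no aromatic ring at all, such as a longer chain ending in an amine or a carboxylic acid.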